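A few compounds are considered here, and "the series" means these few. Any claim that something is new, unique, unknown or untested is made for them only; others in the source may bear on it.

Going by the values given here, compound 2 `Cc1ccc(-c2nn(-c3ccccc3)cc2-c2nc3ccccc3n2S(=O)(=O)c2ccc(Cl)cc2)cc1` gives 5930 nM in a functional assay on MCF7 cells (Homo sapiens) for antiproliferative activity, read by MTT assay, with a stated time of 24 h (on this read-out higher numbers stand for weaker inhibition and lower numbers for stronger inhibition), the highest of the two numbers so far. Compound 1 `Cc1ccc(-c2nn(-c3ccccc3)cc2-c2nc3ccccc3n2S(=O)(=O)c2ccc(C)cc2)cc1` gives 570 nM; the step of a 10-fold higher number from compound 1 to compound 2 (1.02 log units; beyond the scatter) is the only measured one in the series. Compound 3 `O=S(=O)(c1ccc(Cl)cc1)n1c(-c2cn(-c3ccccc3)nc2-c2ccc(F)cc2)nc2ccccc21` differs from compound 2 by fluoro in place of methyl on an aromatic carbon. Among the compounds with values here, no measured pair covers a fluoro in place of methyl on an aromatic carbon; the step from compound 1 to compound 2 concerns chloro in place of methyl and bears on this change only loosely, as an example of how strongly one small aromatic substituent swap can move the number. Within the data shown here, with no direct precedent, no step beyond the scatter is expected in either direction, and the number for compound 3 is expected near that of compound 2, with a wide range. Compound 3 is estimated at 6000 nM (range 2000 nM to 18000 nM), corresponding to an expected step of a 1.0-fold higher number from compound 2 to compound 3 (0.01 log units; within the scatter).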

Compound 3, half-maximal inhibitory concentration: 4960 nM
The estimate for compound 3 lay 1.2-fold (0.08 log units) above the measured number; the range from low to high includes it.
By their numbers in this assay, from the lowest: compound 1; then compounds 3 and 2 (each within the scatter of the next).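

In this assay, the step of a 1.2-fold lower number from compound 2 to compound 3 (0.08 log units; within the scatter) shows that, with the chloro group held fixed, going from 4-methylphenyl to 4-fluorophenyl leaves the number within the scatter. Going by these compounds alone, the only earlier step, a 10-fold higher number from compound 1 to compound 2 (1.02 log units; beyond the scatter), lies at a different place in the molecule, so the large effect seen there does not carry over to this aromatic carbon for this one swap. Nothing at hand explains why this exchange of one heavy atom for another leaves the number unmoved.

From the compounds shown here alone, whether this position accepts larger or different groups, such as an amine, a methoxy group or a carboxylic acid, remains open. Also open, going by these compounds, is whether the same swap stays within the scatter when methyl replaces chloro at the other site, as in compound 1.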